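Trifluoromethoxy in Place of Fluoro on Two Cores

The source may hold more compounds than are shown below. What is called first, only, known or untested is meant among the compounds shown, and "the series" means these compounds.

Measured so far:
Compound 1 `O=C(/C=C/c1ccccc1F)c1cccc(O)c1` gives in a functional assay on RAW264.7 cells (Mus musculus) for inhibition, read by fluorescence, with stated times of 1 h, 24 h and 30 min (a lower number here means a stronger inhibitor, a higher number a weaker inhibitor), a value of > 10000 nM, which is a limit of the assay and not a number.
Compound 2 `O=C(/C=C/c1cccc(F)c1)c1ccccc1` gives in this assay a value of > 10000 nM, again only a limit.
Compound 3 `O=C(/C=C/c1ccccc1OC(F)(F)F)c1cccc(O)c1` gives in this assay a value of 1610 nM.

Compound 3 differs from compound 1 in a single place: trifluoromethoxy in place of fluoro on an aromatic carbon. That change produced an at least 6.2-fold lower number from compound 1 to compound 3 (0.79 log units; beyond the scatter), and the size of this step can only be given as a lower bound, since the limit of > 10000 nM in this assay, at which 2 of the 3 values shown sit, sets the starting point.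

Compound 4 `O=C(/C=C/c1cccc(OC(F)(F)F)c1)c1ccccc1` has not yet been measured. It differs from compound 2 in the same kind of change: trifluoromethoxy in place of fluoro on an aromatic carbon. The two places are not identical, though: in compound 1 the exchanged group sits ortho to a large group, in compound 2 it sits meta to a large group. The cores of compound 1 and compound 2 also differ from each other, and that difference is not broken down here.

For compound 4 the expected step is an at least 2.0-fold lower number from compound 2 to compound 4 (0.30 log units; that floor lies within the scatter), which stands beside an at least 6.2-fold lower number from compound 1 to compound 3 (0.79 log units; beyond the scatter) and rests on that single measured step alone; a change made at a different place on a different core may well give less. Compound 4 is therefore expected at 5000 nM, with a plausible range from 1500 nM to 20000 nM, and a real chance that compound 4 again returns only a limit.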

Compound 4, half-maximal inhibitory concentration: > 10000 nM
Compound 4: only a limit was reported (the forecaster's own chance of this, stated with the estimate: 45%); middle value at least 2.0-fold (0.30 log units) away from the limit.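

Compound 2 and compound 4 each return only a limit and not a number, so the exchange of fluoro for trifluoromethoxy between them gives no step that can be read: the limit of > 10000 nM in this assay, at which 3 of the 4 values shown sit.

The compounds shown leave open whether this exchange changes anything on the core of compound 2, and so whether the gain seen from compound 1 to compound 3 carries over to that core.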